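From pyridin-2-yl to 4-fluoropyridin-2-yl

The source may report more compounds than this note shows. Statements on the series, on what has been measured and on what is new or still open speak of the compounds shown alone.

Within the data shown here, in a physicochemical assay for solubility, read by turbidimetry, measured as kinetic solubility, at pH 6.8 (a lower number here means a less soluble compound, a higher number a more soluble compound), compound 1 `O=C(NCCCCn1cccn1)c1cccc(C2SCC(=O)N2c2ccccn2)c1` gives 50000 nM, the higher of the two numbers so far, while compound 2 `O=C(NCCCCc1ccccc1)c1cccc(C2SCC(=O)N2c2ccccn2)c1` gives 20000 nM. Compound 3 `O=C(NCCCCn1cccn1)c1cccc(C2SCC(=O)N2c2cc(F)ccn2)c1` carries fluoro in place of hydrogen on an aromatic carbon, opposite the ring nitrogen (fluoro in place of hydrogen on an aromatic carbon). Among the measured compounds shown here, the only measured step, a 2.5-fold lower number from compound 1 to compound 2 (0.40 log units; beyond the scatter), is modest but beyond the scatter. It puts phenyl in place of 1H-pyrazol-1-yl on the chain, elsewhere in the molecule, so it is only a rough guide to size. In this assay no change beyond the scatter is expected, and the estimated step is a 1.3-fold lower number from compound 1 to compound 3 (0.10 log units; within the scatter). Compound 3 is expected at 40000 nM, within a range of 20000 nM to 70000 nM.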

Compound 3, solubility: 50000 nM
Beside the measured number, compound 3's estimate is 1.3-fold (0.10 log units) below it, and the stated range covers the measured number.
By their numbers in this assay, from the lowest: compound 2; then compounds 1 and 3 (each within the scatter of the next).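

In this assay, putting fluoro in place of hydrogen on the pyridin-2-yl ring, opposite the ring nitrogen, gives no change at the digits printed from compound 1 to compound 3 (within the scatter), so this position takes a single fluoro with no shift that can be read here. Among these compounds, the only earlier step came from a change on the chain, so this is the first reading at this ring. No measured evidence bears on this result.

As far as these compounds go, whether chloro, methoxy or an amine at the same position would also leave the number in place stays open. From the compounds shown here alone, how fluoro behaves alongside the phenyl chain of compound 2 is also open.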